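The source may report more compounds than this note shows. Statements on the series, on what has been measured and on what is new or still open speak of the compounds shown alone.

Compound 1 `CCCCCCCCc1ccc(OCC(=O)Cn2nnc(-c3ccccn3)n2)cc1` and compound 2 `CCCCCCCCc1ccc(OCC(=O)Cn2nnc(-c3cccs3)n2)cc1` share a core, and in an ADME assay on S9 fraction from liver (Rattus norvegicus) for metabolic stability, read by LC-MS, using NADPH, with a stated time of 30 min (a lower number here means that less of the compound is left, a higher number that more of the compound is left), compound 1 gives 30% while compound 2 gives 8%. The change thiophen-2-yl in place of pyridin-2-yl on an aromatic carbon brings a number 22 percentage points lower from compound 1 to compound 2 (beyond the scatter). Compound 3 `CCCCCCCCc1ccc(OCC(=O)Cn2nnnc2-c2ccccn2)cc1` has the same atoms as compound 1 joined differently; the difference between the two cores is not broken down here. In this assay compound 3 reaches only the limit < 5%, the limit (the limit of < 5% in this assay, at which 1 of the 3 values shown sits). Compound 4 `CCCCCCCCc1ccc(OCC(=O)Cn2nnnc2-c2cccs2)cc1` arises from compound 3 by thiophen-2-yl in place of pyridin-2-yl on an aromatic carbon; this is the same kind of change as from compound 1 to compound 2, but here the thiophen-2-yl stands next to the ring atom that bears a large group rather than two ring bonds from it. Since compound 3 already sits at the limit < 5% and the earlier step lowered the value, compound 4 is expected to stay at or beneath that limit, with an estimated 3%, between 0% and 7%, a step that the limit leaves unreadable from compound 3 to compound 4.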

Compound 4, percent of the compound remaining: 27%
Estimate against measurement, compound 4: 24 percentage points below, outside the stated range (above it).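

In this assay, thiophen-2-yl in place of pyridin-2-yl brings a number at least 22 percentage points higher from compound 3 to compound 4 (beyond the scatter), so the change does not carry from one core to the other with the same direction: the same change on two cores in this assay, a number 22 percentage points lower (beyond the scatter) from compound 1 to compound 2 and a number at least 22 percentage points higher (beyond the scatter) from compound 3 to compound 4, at least 44 percentage points apart, beyond the scatter of two such steps. Compound 3 stands at < 5%, which is a limit of the assay and not a number, so the full size of this step cannot be read. The two pairs show that the outcome of this change depends on the core, but they do not show what in the cores accounts for this, and they give no rule for the series.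

Going by these compounds, it remains open whether a phenyl or furan-2-yl group in the same place would also split between the two cores. On these data alone, it is equally open whether the split would hold with a shorter chain in place of the octyl chain, or with a carboxylic acid at its end.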